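This account rests on a few compounds, and the source may have more. Where it says the series, first, only, none or still open, it means among the compounds named here.

Working notes on the series. Three compounds carry numbers in an assay on CHO-K1 cells for antagonist activity at transient receptor potential cation channel subfamily V member 1 (Homo sapiens), read by FLIPR; a higher number here means a weaker inhibitor, a lower number a stronger inhibitor. Compound 1 `CC1CCN(c2cc(C(F)(F)F)ccc2CNC(=O)C(C)c2ccc3c(c2)CCC3)CC1` gives 96.4 nM. Compound 2 `CC1CCN(c2nc(C(C)(C)C)ccc2CNC(=O)C(C)c2ccc3c(c2)CCC3)CC1` gives 44 nM. Compound 3 `CC(C(=O)NCc1cc(C(F)(F)F)nn1-c1ccc(C(F)(F)F)cc1)c1ccc2c(c1)CCC2` gives 51.3 nM. Compound 3 stands second highest of the three numbers, but its gap to compound 2, the nearest, and its gap to compound 1, the furthest, both lie within the scatter, so no order among the three can be read from these values.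

Compound 4 `Cc1ccc(-n2nc(C(F)(F)F)cc2CNC(=O)C(C)c2ccc3c(c2)CCC3)cc1C` differs from compound 3 in one place: 3,4-dimethylphenyl in place of 4-(trifluoromethyl)phenyl on an aromatic nitrogen. Among the measured compounds shown here, no measured pair shows this change, so the size of the step in this assay cannot be taken from any neighbour; the only guide is that the remainder of compound 4 is unchanged from compound 3. The expected step is a 1.6-fold higher number from compound 3 to compound 4 (0.19 log units; within the scatter), a movement judged likely to stay within the usual scatter or slightly above it. Compound 4 is estimated at 80 nM, with a range from 25 nM to 250 nM.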

Compound 4, inhibition constant: 11.3 nM
Compound 4: middle estimate off by 7.1-fold (0.85 log units), on the high side; measured number outside the range, below it.
By their numbers in this assay, from the lowest: compound 4; then compounds 2, 3 and 1 (each within the scatter of the next, the first and the last beyond it).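

The group on the aromatic nitrogen of the five-membered ring is the one place in the series where a single change can be read: in this assay, 3,4-dimethylphenyl in place of 4-(trifluoromethyl)phenyl gives a 4.5-fold lower number from compound 3 to compound 4 (0.66 log units; beyond the scatter). The number at this position therefore responds to the choice of aryl group, although the two groups match in their six-membered aromatic ring of carbon only and in having no hydrogen-bond donors or acceptors; they differ in heavy-atom count and in carbon against fluorine. Nothing available explains the step.

On these data alone, whether the step comes from losing the trifluoromethyl group or from gaining the two methyl groups stays open. As far as these compounds go, it is also open whether 4-methylphenyl, 3-methylphenyl or a chlorophenyl group on the same nitrogen would give a similar number.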